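The source may report more compounds than this note shows. Statements on the series, on what has been measured and on what is new or still open speak of the compounds shown alone.

Measured in a functional assay on T-24 cells (Homo sapiens) for antiproliferative activity, read by sulforhodamine B assay, with a stated time of 72 h; a lower number here means a stronger inhibitor, a higher number a weaker inhibitor:
compound 1 `C=CCOC(=O)C1=C2C(=NC1=O)c1cccc3cccc2c13`: 3900 nM
compound 2 `CCCSC(=O)COC(=O)C1=C2C(=NC1=O)c1cccc3cccc2c13`: 10500 nM
compound 3 `O=C(COC(=O)C1=C2C(=NC1=O)c1cccc3cccc2c13)OCC(F)(F)C(F)(F)F`: 19000 nM

Compound 1 has the lowest of these numbers in this assay, and its gaps to both others lie beyond the scatter. Compound 4 `C=CCOC(=O)C1=C2C(=NC1=O)c1cccc3c(SCC=C)ccc2c13` differs from compound 1 on the shared core: allylsulfanyl in place of hydrogen on an aromatic carbon. Allylsulfanyl stands in place of hydrogen on an aromatic carbon.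

Two measured steps are available, and neither touches an aromatic carbon. The first, a 2.7-fold higher number from compound 1 to compound 2 (0.43 log units; beyond the scatter), was modest, and the second, a 1.8-fold higher number from compound 2 to compound 3 (0.26 log units; within the scatter), stayed within the scatter. Within the data shown here, they indicate only a rough size of change, since the series holds no other compound substituted on the core. No direction can therefore be argued, and a modest step of either sign is expected. The estimated step is a 1.1-fold lower number from compound 1 to compound 4 (0.05 log units; within the scatter). For compound 4 the expected value is 3500 nM, with an estimated range from 1000 nM to 12000 nM.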

Compound 4, half-maximal inhibitory concentration: 6600 nM
For compound 4 the middle estimate is 1.9-fold (0.28 log units) below the measured one, and the stated range covers the measured number.
By their numbers in this assay, from the lowest: compounds 1, 4, 2 and 3 (each within the scatter of the next, the first and the last beyond it).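

In this assay, among these compounds, a 1.7-fold higher number from compound 1 to compound 4 (0.23 log units; within the scatter) gives the first reading of a change on the shared core, as the earlier steps concerned only the chain on the carbonyl. Allylsulfanyl brings 4 heavy atoms to this aromatic carbon, yet compound 4 stays within the scatter of compound 1, so this single change shows no measurable loss or gain at this position. Nothing shown explains this outcome.

From the compounds shown here alone, it remains open whether a different group on the same carbon, such as an amine, a methoxy group or a longer alkylsulfanyl chain, would also stay within the scatter of compound 1. Going by these compounds, it is equally open whether allylsulfanyl would read the same way on the core of compound 2 or compound 3, with their longer chains.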